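The compounds below may be only part of what the source reports. "The series", "measured", "known", "first", "only" and "open" are said of these compounds alone.

In a functional assay on HeLa cells (Homo sapiens) for cytotoxicity, read by MTT assay, with a stated time of 48 h (a lower number here means that less compound is needed, a higher number that more compound is needed for the effect), compound 1 (`CS(=O)(=O)c1ccc(Cc2n[nH]c(=S)n2/N=C/c2ccc(Cl)cc2)cc1`) gives 50000 nM. Compound 2 (`COc1ccc2cc(/C=N/n3c(Cc4ccc(S(C)(=O)=O)cc4)n[nH]c3=S)ccc2c1`) gives 50000 nM, so the two stand level, with no gap between them at the digits reported. Within the data shown here, these two results are the only measurements so far, and the two structures differ by more than a single swap, so they offer no clean one-place comparison.

The next molecule is compound 3 (`CS(=O)(=O)c1ccc(Cc2n[nH]c(=S)n2/N=C/c2cccs2)cc1`), which has not yet been tested. Compared with compound 1, it carries thiophen-2-yl in place of 4-chlorophenyl on a carbon with a double bond to nitrogen, while the rest of the structure stays the same: thiophen-2-yl in place of 4-chlorophenyl on a carbon with a double bond to nitrogen.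

Among the measured compounds shown here, with no measured step to serve as a direct guide for this swap, the best available clue is the level shared by the two measured compounds. No step beyond the usual scatter is expected in this assay, in either direction, since compound 2 also gives 50000 nM. The expected step is no change at the digits printed from compound 1 to compound 3 (within the scatter). For compound 3 the estimated value is 50000 nM, with an expected range from 20000 nM to 100000 nM.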

Compound 3, half-maximal effective concentration: 100000 nM
Compound 3: the middle estimate sits 2.0-fold (0.30 log units) below what was measured; the measured number falls inside the stated range.
By their numbers in this assay, from the lowest: compounds 1, 2 and 3 (each within the scatter of the next).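

In this assay, among these compounds, this is the first comparison that isolates one place, the group on a carbon with a double bond to nitrogen, and replacing 4-chlorophenyl with thiophen-2-yl gives a 2.0-fold higher number from compound 1 to compound 3 (0.30 log units; within the scatter). The swap is not a small one on paper: a six-membered aromatic ring of carbon only gives way to a five-membered aromatic ring with one hetero atom, the chlorine leaves, the heavy-atom count falls from 7 to 5, and one hydrogen-bond acceptor enters, yet the reading stays within the usual scatter, so this assay does not separate these two groups. Nothing available explains why the reading responds so little to this swap.

Neither of these two aromatic groups shows what a different kind of group at this carbon would do, such as an amine, a carboxylic acid or a longer alkyl chain. As far as these compounds go, it also remains open whether any change at this place, or elsewhere on the core of compound 1, could bring the number clearly down in this assay.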